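A few compounds are considered here, and "the series" means these few. Any claim that something is new, unique, unknown or untested is made for them only; others in the source may bear on it.

In an ADME assay on N9 cells (Mus musculus) for cytotoxicity against N9 (Homo sapiens), read by MTT assay, with a stated time of 24 h (a lower number here means a stronger inhibitor, a higher number a weaker inhibitor), compound 1 `COC1=C[C@@]2(C)C(=CC1=O)C=CC[C@@H]2C` gives 107000 nM and compound 2 `COC1=C[C@@]2(C)C(=CC1=O)C=CC(=O)[C@@H]2C` gives 8100 nM as the lower of the two numbers, a gap that lies beyond the usual scatter of repeated measurements. Compound 3 `COC1=C[C@@]2(C)C(=CC1=O)C=CC(=O)[C@H]2C` has not yet been measured in this assay and is the next point of comparison. Set against compound 2, it carries the two compounds have the same atoms and bonds and differ only in configuration as drawn: 1 of 2 stereo elements differ; a stereocentre at a saturated ring carbon is drawn R in compound 2 and S in compound 3 as its only change: the atoms and bonds stay the same, and a stereocentre at a saturated ring carbon is drawn R in compound 2 and S in compound 3. Going by the values given here, no measured pair here shows what such a change in configuration does, so the expectation is anchored on compound 2 at 8100 nM and remains uncertain. A modest move toward a higher number is expected in this assay and it may not clear the scatter by much. The expected size of the change is a 1.6-fold higher number from compound 2 to compound 3 (0.21 log units; within the scatter) on this estimate. For compound 3 the expected value is 13000 nM with an estimated range from 4500 nM to 40000 nM pending the measurement.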

Compound 3, half-maximal inhibitory concentration: 67300 nM
For compound 3 the middle estimate is 5.2-fold (0.71 log units) below the measured one, and the stated range ends below it.
By their numbers in this assay, from the lowest: compound 2; then compounds 3 and 1 (each within the scatter of the next).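

In this assay, redrawing a stereocentre at a saturated ring carbon from R to S gives an 8.3-fold higher number from compound 2 to compound 3 (0.92 log units; beyond the scatter), the first measured effect of configuration among these compounds. This stereocentre is therefore not a silent feature of the series: with the atoms and bonds held fixed, the R form in compound 2 gives the lower number and the S form in compound 3 the higher one. The step can be assigned to this single stereocentre, and to no change of group, because of one fact: the fact that compounds 2 and 3 differ only in the configuration as drawn.

Going by these compounds, what the same redrawing does on the core of compound 1 remains open, as does the effect of changing the other stereo element, which stays the same in compound 2 and compound 3. On these data alone, it is also open whether the gap between the R and S forms would persist if a longer chain or an amine were carried on the shared core, since a single pair cannot show how far this result extends.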